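Trading the methoxyphenyl for a trifluoromethylphenyl

The source may report more compounds than this note shows. Statements on the series, on what has been measured and on what is new or still open speak of the compounds shown alone.

For the measured compounds named here, compound 2 `COc1ccc(-c2cn3ccnc3c(-c3ccc4ncn(C5CCCCC5)c4c3)n2)cc1` stands highest of the three compounds measured so far in a functional assay on HT-29 cells (Homo sapiens) for inhibition, read by sulforhodamine B assay, with a stated time of 48 h, tested at 10 uM; on this read-out higher numbers stand for more inhibition at the one concentration tested (going by the name of the read-out) and lower numbers for less inhibition: compound 2 gives 92.5%. Compound 1 `c1ccc(-c2cn3ccnc3c(-c3ccc4ncn(C5CCCCC5)c4c3)n2)cc1` gives 48.3%, and compound 3 `c1cn2cc(-c3ccsc3)nc(-c3ccc4ncn(C5CCCCC5)c4c3)c2n1` gives 5.68%. The change from compound 2 to compound 4 `FC(F)(F)c1cccc(-c2cn3ccnc3c(-c3ccc4ncn(C5CCCCC5)c4c3)n2)c1` is 3-(trifluoromethyl)phenyl in place of 4-methoxyphenyl on an aromatic carbon. The entering group carries no hydrogen-bond acceptor, whereas the leaving group carries one. The step that bears most directly on this is a number 44.2 percentage points higher from compound 1 to compound 2 (beyond the scatter), and the step of a number 86.8 percentage points lower from compound 2 to compound 3 (beyond the scatter) is larger still; both show that compound 2 owes much of its standing to the methoxy. A downward step is therefore expected, a number 52.5 percentage points lower from compound 2 to compound 4 (beyond the scatter). Compound 4 is estimated at 40%, with a range from 10% to 75%.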

Compound 4, a percentage reported as inhibition, at one concentration (the size of the read-out at that concentration, not a potency): 6.41%
Beside the measured number, compound 4's estimate is 33.6 percentage points above it; the whole stated range lies above it.
By their numbers in this assay, from the lowest: compounds 3 and 4 (each within the scatter of the next); then compound 1; then compound 2.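

In this assay, the 3-(trifluoromethyl)phenyl group does not keep what the 4-methoxyphenyl group gives (a number 86.1 percentage points lower from compound 2 to compound 4 (beyond the scatter)), and it also falls short of unsubstituted phenyl (a number 41.9 percentage points lower from compound 1 to compound 4 (beyond the scatter)). A substituent on this phenyl ring can therefore lower the read-out as well as raise it. Set against the thiophen-3-yl group, the trifluoromethylphenyl group shows no real difference (a number 0.7 percentage points higher from compound 3 to compound 4 (within the scatter)). Nothing at hand explains these differences. Still open, as far as these compounds go, is whether the loss follows the trifluoromethyl group itself or its placement on the ring, and whether an amine or a hydroxyl on the phenyl ring would match compound 2.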